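This account rests on a few compounds, and the source may have more. Where it says the series, first, only, none or still open, it means among the compounds named here.

Compound 1 `CC(=O)c1ccc2[nH]c(-c3ccccc3)nc2c1`: > 100000 nM, a limit
Compound 2 `CC(=O)c1ccc2[nH]c(-c3ccc(Cl)cc3)nc2c1`: > 100000 nM, a limit
Compound 3 `COc1ccc(-c2nc3cc(C(C)=O)ccc3[nH]2)c(OC)c1`: 73000 nM

These results come from an ADME assay on MDBK cells (Bos taurus) for cytotoxicity, read by MTT assay, with a stated time of 96 h; on this read-out lower numbers stand for higher toxicity in this test and higher numbers for lower toxicity in this test. Compound 3 is the only one of the three with an actual number. The other two entries are the limit of > 100000 nM in this assay, at which 2 of the 3 values shown sit.

Compound 4 `COc1ccc(-c2nc3cc(C(C)=O)ccc3[nH]2)c(OC)c1OC` differs from compound 3 in one place: methoxy in place of hydrogen on an aromatic carbon. This is methoxy in place of hydrogen on an aromatic carbon, ortho to two methoxy groups.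

Going by the values given here, the one measured step, a step that the two limits leave unreadable from compound 1 to compound 2, involves chloro rather than methoxy and offers no size to carry over. No shift beyond the usual scatter is therefore expected, and the estimated change is a 1.0-fold higher number from compound 3 to compound 4 (0.01 log units; within the scatter).

For compound 4, the expected value is 75000 nM, with an estimated range of 35000 nM to 100000 nM.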

Compound 4, half-maximal cytotoxic concentration: > 100000 nM
Compound 4: a limit, no number; the forecaster's own chance of this, stated with the estimate: 35%; middle value at least 1.3-fold (0.12 log units) from the limit.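

Methoxy in place of hydrogen at this position, ortho to two methoxy groups, gives an at least 1.3-fold higher number from compound 3 to compound 4 (0.13 log units; that floor lies within the scatter) in this assay. The result for compound 4 is a limit and not a number, so this change shows no sign of higher toxicity in this test. Only a floor for the step can be read, and its true size stays unknown: the limit of > 100000 nM in this assay, at which 3 of the 4 values shown sit.

From the compounds shown here alone, whether an amine or a carboxylic acid at this position would move the number, and in which direction, stays open. Steps between compounds that both rest at the limit cannot be read.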